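The source may report more compounds than this note shows. Statements on the series, on what has been measured and on what is new or still open speak of the compounds shown alone.

Compounds measured so far: compound 1 `COc1ccc(C2OC(c3cc(OC)c(OC)c(OC)c3)=NN2C(C)=O)c(OC)c1` gives 92%; compound 2 `COc1cc(C2=NN(C(C)=O)C(c3ccc(C(F)(F)F)cc3)O2)cc(OC)c1OC` gives -0.7%; compound 3 `COc1cc(C2=NN(C(C)=O)C(c3cccc(F)c3)O2)cc(OC)c1OC` gives 43.5%.

In a functional assay on PC-3 cells (Homo sapiens) for antiproliferative activity, read by MTT assay, tested at 5 uM (on this read-out lower numbers stand for a weaker effect and higher numbers for a stronger effect at the one concentration tested), compound 3 stands second highest of the three numbers: the step of a number 44.2 percentage points higher from compound 2 to compound 3 (beyond the scatter) and the step of a number 48.5 percentage points lower from compound 1 to compound 3 (beyond the scatter) were both large. Compound 4 `COc1cc(C2=NN(C(C)=O)C(c3ccc(Cl)c([N+](=O)[O-])c3)O2)cc(OC)c1OC` has not yet been measured; it differs from compound 3 in one place: 4-chloro-3-nitrophenyl in place of 3-fluorophenyl on a saturated ring carbon. Among the compounds with values here, no measured step brings in a 4-chloro-3-nitrophenyl group, so the only guide is that the group on this saturated ring carbon shifts the read-out widely, from compound 2 up to compound 1. The expected step of a number 13.5 percentage points lower from compound 3 to compound 4 (beyond the scatter) is therefore uncertain, with a drop judged somewhat more likely than a rise. Compound 4 is estimated at 30%, within 0% to 70%.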

Compound 4, a percentage reported as inhibition, at one concentration (the size of the read-out at that concentration, not a potency): 61.4%
Compound 4: the middle estimate sits 31.4 percentage points below what was measured; low and high end bracket the measured number.
By their numbers in this assay, from the lowest: compound 2; then compound 3; then compound 4; then compound 1.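

In this assay, 4-chloro-3-nitrophenyl on this saturated ring carbon gives a middle result: the read-out is a number 17.9 percentage points higher from compound 3 to compound 4 (beyond the scatter) and a number 62.1 percentage points higher from compound 2 to compound 4 (beyond the scatter) but also a number 30.6 percentage points lower from compound 1 to compound 4 (beyond the scatter) for the change at the same place. Among these four compounds, a phenyl group without methoxy groups can therefore keep a sizeable read-out, although 2,4-dimethoxyphenyl still gives the highest. Nothing available explains this order. The compounds shown leave open whether the chlorine or the nitro group matters more on its own. They also leave open how an amine or a carboxylic acid on this phenyl ring would behave.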